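The source may report more compounds than this note shows. Statements on the series, on what has been measured and on what is new or still open speak of the compounds shown alone.

Measured in a functional assay on LoVo cells (Homo sapiens) for inhibition, read by colorimetric assay and MTT assay, with a stated time of 72 h; on this read-out lower numbers stand for stronger inhibition and higher numbers for weaker inhibition:
- compound 1 `CCCCOc1ncc(-c2ccccc2OC)n1C`: 39000 nM
- compound 2 `CCCCCCOc1ncc(-c2ccccc2OC)n1C`: 27000 nM
- compound 3 `COc1ccccc1-c1cnc(OC)n1C`: 73000 nM

Compound 3 lies within the scatter of compound 1, with a 1.9-fold higher number from compound 1 to compound 3 (0.27 log units; within the scatter). It lies beyond the scatter of compound 2, with a 2.7-fold higher number from compound 2 to compound 3 (0.43 log units; beyond the scatter).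

Next is compound 4 `C=CCCCCOc1ncc(-c2ccccc2OC)n1C`. The change is pent-4-en-1-yl in place of hydrogen on a saturated chain carbon bound to an oxygen on an aromatic ring.

The two steps above bear on this change when read in reverse, since each has hydrogen replacing a chain at that place. Only the pentyl step clears the scatter, and it is modest. The step of a 1.4-fold lower number from compound 1 to compound 2 (0.16 log units; within the scatter) stays within the scatter. Among the compounds with values here, no measured compound carries a double bond outside aromatic rings, so that feature remains untested.

A modest move toward a lower number is therefore expected in this assay. The expected step is a 2.4-fold lower number from compound 3 to compound 4 (0.39 log units; beyond the scatter). For compound 4 the estimated value is 30000 nM, with an expected range of 15000 nM to 55000 nM.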

Compound 4, half-maximal inhibitory concentration: 4000 nM
Compound 4: the middle estimate sits 7.5-fold (0.88 log units) above what was measured; the measured number lies below the stated range.
By their numbers in this assay, from the lowest: compound 4; then compounds 2, 1 and 3 (each within the scatter of the next, the first and the last beyond it).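

In this assay, the chain end is where the series responds: vinyl in place of ethyl gives a 6.8-fold lower number from compound 2 to compound 4 (0.83 log units; beyond the scatter), although lengthening the saturated chain alone stayed small, with a 1.4-fold lower number from compound 1 to compound 2 (0.16 log units; within the scatter). Measured against the shorter saturated chain, vinyl in place of hydrogen gives a 9.8-fold lower number from compound 1 to compound 4 (0.99 log units; beyond the scatter), and against the methoxy compound, pent-4-en-1-yl in place of hydrogen gives an 18-fold lower number from compound 3 to compound 4 (1.26 log units; beyond the scatter), the largest step in the series, so chain length alone does not account for this result. No measurement shown explains why the unsaturated chain end makes this difference.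

Open, going by these compounds, is whether the double bond must sit at the chain end, or whether a triple bond there would serve equally. Also open, on these data alone, is how a longer chain ending in vinyl, or a chain ending in an amine or a carboxylic acid, would read out.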